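Stability in mouse liver microsomes: from compound 3 to compound 4

The source may hold more compounds than are shown below. What is called first, only, known or untested is meant among the compounds shown, and "the series" means these compounds.

Measured so far:
- compound 1, `O=C(NCc1ccc(S(=O)(=O)N2CCCCC2)cc1)c1ccn2cncc2c1`: 1%
- compound 2, `O=C(NCc1ccc(S(=O)(=O)c2ccccc2)cc1)c1ccc2ccncc2c1`: 3.3%
- compound 3, `O=C(NCc1ccc(S(=O)(=O)c2ccccc2C(F)(F)F)cc1)c1cc2cnccc2[nH]1`: 41%

All three were tested in an ADME assay on microsomes from liver (Mus musculus) for metabolic stability, read by LC-MS, with a stated time of 30 min, tested at 1 uM; on this read-out higher numbers stand for a more stable compound and lower numbers for a less stable compound. Compound 3 stands highest of the three numbers, and both gaps, to compound 2 and to compound 1, lie beyond the scatter of repeated measurements, so compound 3 is clearly the most stable of the three. Among the measured compounds shown here, compound 1 and compound 2 each carry a different core and a different group on the sulfonyl sulfur, so no single step between measured compounds can be drawn.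

The next compound, compound 4, `O=C(NCc1ccc(S(=O)(=O)c2cccc(F)c2)cc1)c1cc2cnccc2[nH]1`, keeps the core of compound 3 and changes only the group on the sulfonyl sulfur: 3-fluorophenyl in place of 2-(trifluoromethyl)phenyl on a sulfonyl sulfur.

For the measured compounds named here, no measured pair shows this exact change, so any expectation rests on compound 3 alone, which gives 41% in this assay. A downward step beyond the scatter is expected in this assay, a number 17 percentage points lower from compound 3 to compound 4 (beyond the scatter), since compound 4 moves away from the only arrangement seen to give a high number. Compound 4 is estimated at 24%, within a range from 7% to 50%.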

Compound 4, percent of the compound remaining: 44%
For compound 4 the middle estimate is 20 percentage points below the measured one; the range from low to high includes it.
By their numbers in this assay, from the lowest: compounds 1 and 2 (each within the scatter of the next); then compounds 3 and 4 (each within the scatter of the next).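

In this assay, putting 3-fluorophenyl in place of 2-(trifluoromethyl)phenyl on a sulfonyl sulfur gives a number 3 percentage points higher from compound 3 to compound 4 (within the scatter), so the two compounds cannot be told apart on this read-out. This is the first pair shown that differs in one place only, and it shows that the number for compound 3 does not depend on 2-(trifluoromethyl)phenyl: on the shared core, a group of 7 heavy atoms with a single fluorine serves as well as one of 10 heavy atoms with three fluorines. No measurement shown here offers an explanation for this match between the two groups.

From the compounds shown here alone, compound 1 and compound 2 each differ from these two in both the core and the group on the sulfonyl sulfur, so steps to them cannot be read, and it stays open whether the core or that group matters more for the wider gap in the numbers. Going by these compounds, it also stays open whether this position would accept a group of another kind on the same core, such as a morpholine ring, an amine or a carboxylic acid, as readily as these two fluorinated phenyl groups.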